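Moving the fluorine around the aryl ring

A few compounds are considered here, and "the series" means these few. Any claim that something is new, unique, unknown or untested is made for them only; others in the source may bear on it.

Measured compounds:
compound 1 `Cc1cccc(-c2nc(C)c(COc3ccc4c(c3)OCC4CC(=O)O)s2)c1` — 119 nM
compound 3 `Cc1nc(-c2cccc(F)c2)sc1COc1ccc2c(c1)OCC2CC(=O)O` — 64.8 nM
compound 2 `Cc1nc(-c2ccccc2Cl)sc1COc1ccc2c(c1)OCC2CC(=O)O` — "not determined" (no result reported)

In a functional assay on CHO cells for agonist activity at Free fatty acid receptor 1 (Homo sapiens), read by FLIPR and calcium flux (on this read-out lower numbers stand for an effect already at smaller amounts and higher numbers for an effect only at larger amounts of compound), compound 1 gives 119 nM and compound 3 gives 64.8 nM. For compound 2 the read-out is recorded only as "not determined" (no result reported), so it contributes no number. Going by the values given here, compound 3 therefore carries the lower of the two available numbers, yet the single measured step, a 1.8-fold lower number from compound 1 to compound 3 (0.26 log units; within the scatter), lies within the scatter, so compound 1 and compound 3 cannot be told apart on this evidence.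

Compound 4 `Cc1nc(-c2ccc(F)cc2)sc1COc1ccc2c(c1)OCC2CC(=O)O` is the next compound. It differs from compound 3 in one place: 4-fluorophenyl in place of 3-fluorophenyl on an aromatic carbon. The two compounds contain the same atoms, joined differently. Among the compounds with values here, no measured step involves a move of a fluorine from one position of the phenyl ring to another; the only measured step, a 1.8-fold lower number from compound 1 to compound 3 (0.26 log units; within the scatter), swaps a methyl for a fluoro and does not speak to this change. With nothing pointing either way, the expectation is a step of a 1.4-fold higher number from compound 3 to compound 4 (0.14 log units; within the scatter) that stays within the scatter. Compound 4 is therefore estimated at 90 nM in this assay, with a range from 30 nM to 300 nM.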

Compound 4, half-maximal effective concentration: 48.7 nM
The estimate for compound 4 lay 1.8-fold (0.27 log units) above the measured number; the range from low to high includes it.
By their numbers in this assay, from the lowest: compounds 4, 3 and 1 (each within the scatter of the next, the first and the last beyond it).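

Moving the fluorine, with 4-fluorophenyl in place of 3-fluorophenyl on an aromatic carbon of the five-membered ring, gives a 1.3-fold lower number from compound 3 to compound 4 (0.12 log units; within the scatter) in this assay, so these two placings of the fluorine cannot be told apart on this read-out. The exchange of 3-methylphenyl for 4-fluorophenyl gives a 2.4-fold lower number from compound 1 to compound 4 (0.39 log units; beyond the scatter), a modest step, whereas the exchange for 3-fluorophenyl gave a 1.8-fold lower number from compound 1 to compound 3 (0.26 log units; within the scatter); the group and its place on the phenyl ring change together in this step, so the compounds shown cannot assign the gap to either one. No measurement is available here that would explain these numbers.

Compound 2 has a chlorine on its phenyl ring but gives no number, so it says nothing about how a chlorine compares with a fluorine at this position. As far as these compounds go, whether a larger or differently built group, such as a trifluoromethyl, a nitrile or a methoxy group in place of the fluorine, would keep numbers of this size remains open.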